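This account rests on a few compounds, and the source may have more. Where it says the series, first, only, none or still open, it means among the compounds named here.

Measured so far:
compound 1, `COc1ccccc1C(=O)Nc1nnc(SCC(=O)Nc2ccc(Cl)cn2)s1`, > 80000 nM
compound 2, `COc1ccccc1C(=O)Nc1nnc(SCC(=O)Nc2c(C)ccnc2Cl)s1`, > 80000 nM
compound 3, `O=C(CSc1nnc(NC(=O)CCl)s1)Nc1ccc(Cl)cn1`, 8600 nM

In a functional assay on A875 cells (Homo sapiens) for antiproliferative activity, read by MTT assay, with a stated time of 48 h (a lower number here means a stronger inhibitor, a higher number a weaker inhibitor), compound 1 gives > 80000 nM, which is a limit of the assay and not a number. In this assay compound 2 likewise gives > 80000 nM, again a limit rather than a number. In this assay compound 3 gives 8600 nM.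

Two single changes connect these compounds. The change 2-chloro-4-methylpyridin-3-yl in place of 5-chloropyridin-2-yl on an amide-type nitrogen gives a step that the two limits leave unreadable from compound 1 to compound 2, because of the limit of > 80000 nM in this assay, at which 2 of the 3 values shown sit. The change chloromethyl in place of 2-methoxyphenyl on a carbonyl carbon gives a step of an at least 9.3-fold lower number from compound 1 to compound 3 (0.96 log units; beyond the scatter).

Compound 4, `Cc1ccnc(Cl)c1NC(=O)CSc1nnc(NC(=O)CCl)s1`, is not yet measured. It differs from compound 2 by chloromethyl in place of 2-methoxyphenyl on a carbonyl carbon. Among the compounds with values here, this is the same change as the one from compound 1 to compound 3, and the place is described in the same words for both pairs, so the two steps are the same change on cores that differ by 2-chloro-4-methylpyridin-3-yl in place of 5-chloropyridin-2-yl on an amide-type nitrogen.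

The measured step of an at least 9.3-fold lower number from compound 1 to compound 3 (0.96 log units; beyond the scatter) is the guide here. Since compound 2 starts from a limit just as compound 1 does, the corresponding step in this assay is expected to be of similar size, and the expected step is an at least 5.3-fold lower number from compound 2 to compound 4 (0.72 log units; beyond the scatter). On that basis compound 4 is expected to give about 15000 nM in this assay, most likely between 5000 nM and 80000 nM.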

Compound 4, half-maximal inhibitory concentration: 34700 nM
For compound 4 the middle estimate is 2.3-fold (0.36 log units) below the measured one; the range from low to high includes it.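

In this assay, chloromethyl in place of 2-methoxyphenyl on a carbonyl carbon gives an at least 2.3-fold lower number from compound 2 to compound 4 (0.36 log units; beyond the scatter), so the change lowers the number on both cores, and the direction carries from the core of compound 1 to the core of compound 2: the same change on two cores in this assay, an at least 9.3-fold lower number (0.96 log units; beyond the scatter) from compound 1 to compound 3 and an at least 2.3-fold lower number (0.36 log units; beyond the scatter) from compound 2 to compound 4; the limit leaves it open whether they differ

The size of the step does not carry in any readable way, and neither does the step between compound 1 and compound 2, which cannot be read, because the starting values of both cores are limits of the assay and not numbers: the limit of > 80000 nM in this assay, at which 2 of the 4 values shown sit.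

Within the data shown here, with chloromethyl in place, compound 3 gives 8600 nM and compound 4 gives 34700 nM, and these two values are the only actual numbers the series offers, while the two compounds carrying 2-methoxyphenyl fix only the far end of the range.

The compounds shown leave open whether the chlorine of the chloromethyl group matters, as a plain methyl, a bromomethyl or a longer chain on the same carbonyl carbon would be needed to tell. They also leave open whether the change holds on an amide-type nitrogen bearing something other than these two chloropyridine groups, such as an unsubstituted phenyl.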